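The source may hold more compounds than are shown below. What is called first, only, known or untested is meant among the compounds shown, and "the series" means these compounds.

Measured so far:
compound 1 `O=C(CCC(=O)OCCCCCCSc1ccc([N+](=O)[O-])c2nonc12)Nc1ccccc1F` — 9890 nM
compound 2 `CN(C)CCCNC(=O)CCC(=O)OCCCCCCSc1ccc([N+](=O)[O-])c2nonc12` — 160 nM

In an assay on isolated protein for inhibition of glutathione S-transferase P (Homo sapiens), with a stated time of 10 min (on this read-out lower numbers stand for stronger inhibition and higher numbers for weaker inhibition), compound 2 holds the lowest of the two numbers; its nearest neighbour, compound 1, gives 9890 nM. Compound 3 `O=C(CCC(=O)N1CCCCC1)OCCCCCCSc1ccc([N+](=O)[O-])c2nonc12` differs from compound 2 by piperidin-1-yl in place of (3-(dimethylamino)propyl)amino on a carbonyl carbon. For the measured compounds named here, one measured step bears on this part of the molecule: a 62-fold lower number from compound 1 to compound 2 (1.79 log units; beyond the scatter). Compound 3 removes the very group that went with that lower number, so a higher number in this assay is expected, roughly a 13-fold higher number from compound 2 to compound 3 (1.10 log units; beyond the scatter). Compound 3 is therefore estimated at 2000 nM, with a range from 400 nM to 10000 nM.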

Compound 3, half-maximal inhibitory concentration: 500 nM
For compound 3 the middle estimate is 4.0-fold (0.60 log units) above the measured one; the measured number falls inside the stated range.
By their numbers in this assay, from the lowest: compound 2; then compound 3; then compound 1.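

In this assay, piperidin-1-yl on the carbonyl carbon costs only part of the potency, with a 3.1-fold higher number from compound 2 to compound 3 (0.49 log units; beyond the scatter), and it still gives a 20-fold lower number from compound 1 to compound 3 (1.30 log units; beyond the scatter). Low numbers at this position therefore do not require the open (3-(dimethylamino)propyl)amino chain or a hydrogen-bond donor on the amide nitrogen. Nothing available explains these differences.

As far as these compounds go, it remains open whether the terminal dimethylamino group accounts for the advantage of compound 2 over compound 3. A plain pentylamino chain, which lacks that amine, or a 4-methylpiperazin-1-yl ring, which puts an amine back into the ring, could help separate amine from shape.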